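Replacing an ester side chain with a saturated ring

The compounds below may be only part of what the source reports. "The series", "measured", "known", "first", "only" and "open" are said of these compounds alone.

Three related compounds share one core and differ only in the acid part of an ester. Compound 1 `CC(C)=CC[C@@H](OC(=O)C1CCOC1)C1=CC(=O)c2c(O)ccc(O)c2C1=O` gives 47500 nM in a functional assay on DU-145 cells (Homo sapiens) for cytotoxicity, read by MTT assay; on this read-out higher numbers stand for weaker inhibition and lower numbers for stronger inhibition. Compound 2 `CCCCC(C)(O)CC(=O)O[C@H](CC=C(C)C)C1=CC(=O)c2c(O)ccc(O)c2C1=O` gives 76500 nM in this assay, and compound 3 `CCCC(CC(=O)O[C@H](CC=C(C)C)C1=CC(=O)c2c(O)ccc(O)c2C1=O)OC(C)=O` gives 55700 nM in this assay. Among these three numbers compound 3 stands second highest. The smallest gap is a 1.2-fold higher number from compound 1 to compound 3 (0.07 log units; within the scatter), the largest is a 1.4-fold lower number from compound 2 to compound 3 (0.14 log units; within the scatter), and between the remaining pair the gap is a 1.6-fold higher number from compound 1 to compound 2 (0.21 log units; within the scatter). None of these three steps rises beyond the scatter of repeated measurements, so on this read-out the three compounds cannot be told apart.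

Compound 4 `CC(C)=CC[C@@H](OC(=O)C1CCCOC1)C1=CC(=O)c2c(O)ccc(O)c2C1=O` has not been measured. Its structure differs from that of compound 3 in one place: oxan-3-yl in place of 2-acetoxypentyl on a carbonyl carbon. The measured step that bears on it most closely is a 1.2-fold higher number from compound 1 to compound 3 (0.07 log units; within the scatter), where a small saturated ring was exchanged for the very chain that is now removed again, and that step stayed within the scatter; the other two steps did likewise. The step of a 1.1-fold lower number from compound 3 to compound 4 (0.05 log units; within the scatter) is therefore expected to stay within the scatter, with no direction favoured. Compound 4 is estimated at 50000 nM, with a range from 25000 nM to 100000 nM.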

Compound 4, half-maximal inhibitory concentration: 29700 nM
Compound 4: middle estimate off by 1.7-fold (0.23 log units), on the high side; the range from low to high includes it.
By their numbers in this assay, from the lowest: compounds 4, 1, 3 and 2 (each within the scatter of the next, the first and the last beyond it).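

In this assay, for the compounds shown here, the exchange of 2-hydroxy-2-methylhexyl for oxan-3-yl on the carbonyl carbon gives a 2.6-fold lower number from compound 2 to compound 4 (0.41 log units; beyond the scatter), the first step to pass the scatter, so the acid part of the ester is not entirely silent on this read-out. Going by these compounds alone, the other two exchanges, a 1.9-fold lower number from compound 3 to compound 4 (0.27 log units; within the scatter) and a 1.6-fold lower number from compound 1 to compound 4 (0.20 log units; within the scatter), stay within the scatter, so oxan-3-yl cannot be told apart from either 2-acetoxypentyl or oxolan-3-yl, and only the pair with the branched hydroxy chain separates. Nothing available explains why this one pair separates.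

The compounds shown leave open what would happen with an amine or a carboxylic acid on the oxan-3-yl ring, or with a phenyl ring in its place on the carbonyl carbon, since every group here is either a saturated ring with one oxygen or an open chain bearing a hydroxyl or acetoxy group. Within the data shown here, they also leave open whether the single step beyond the scatter would hold up in a different cell line, as all four numbers come from this assay.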